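The source may hold more compounds than are shown below. What is called first, only, known or untested is meant among the compounds shown, and "the series" means these compounds.

Measured compounds:
Compound 1, `COc1cc(-c2cc(/C=C/C(=O)c3ccc(N)cc3)[nH]n2)cc(OC)c1OC`, gives 10500 nM in a functional assay on IGROV-1 cells (Homo sapiens) for inhibition, read by sulforhodamine B assay, with a stated time of 48 h; a lower number here means a stronger inhibitor of growth, a higher number a weaker inhibitor of growth.
Compound 2, `COc1ccc(-c2cc(/C=C/C(=O)c3ccc(N)cc3)[nH]n2)cc1OC`, gives 19000 nM.
Compound 3, `COc1cc(C(=O)/C=C/c2cc(-c3cc(OC)c(OC)c(OC)c3)n[nH]2)cc(OC)c1OC`, gives 10200 nM.

Among the compounds with values here, all three numbers sit close together, and no pair of them is separated by more than the usual scatter, so none of the three can be called the stronger or weaker growth inhibitor on this evidence. Compound 1 and compound 3 carry different cores; how those cores differ is not broken down here. Compound 2 differs from compound 1 in a single place: hydrogen in place of methoxy on an aromatic carbon. That change produced a 1.8-fold higher number from compound 1 to compound 2 (0.26 log units; within the scatter).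

Compound 4, `COc1ccc(-c2cc(/C=C/C(=O)c3cc(OC)c(OC)c(OC)c3)[nH]n2)cc1OC`, has not yet been measured in this assay. It differs from compound 3 by the same change at the same place: hydrogen in place of methoxy on an aromatic carbon. Within the data shown here, only one measured instance of this change exists, and it gave a 1.8-fold higher number from compound 1 to compound 2 (0.26 log units; within the scatter), so a small step of similar size is expected here. The expected step is a 1.7-fold higher number from compound 3 to compound 4 (0.22 log units; within the scatter). Compound 4 is accordingly estimated at 17000 nM, with the likely range running from 8000 nM to 38000 nM.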

Compound 4, concentration for total growth inhibition: 8610 nM
Compound 4: middle estimate off by 2.0-fold (0.30 log units), on the high side; low and high end bracket the measured number.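

In this assay, putting hydrogen in place of methoxy on the aromatic carbon gave a 1.2-fold lower number from compound 3 to compound 4 (0.07 log units; within the scatter). Set beside the earlier case, the two steps do not differ by more than repeat measurements normally would: the same change on two cores in this assay, a 1.8-fold higher number (0.26 log units; within the scatter) from compound 1 to compound 2 and a 1.2-fold lower number (0.07 log units; within the scatter) from compound 3 to compound 4, 2.1-fold (0.33 log units) apart, within the scatter of two such steps. Within the data shown here, the change can therefore be carried between the core of compound 1 and the core of compound 3 without any difference that stands out from the scatter, but both steps are so small that this shows only that the swap made no clear difference on either core, not that it has a real effect of a set size or direction that transfers.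

The compounds shown leave open whether a different group at this place, such as a carboxylic acid, a fluorine atom or a longer chain like butoxy, would shift the number beyond the scatter. They also leave open how the same swap of methoxy for hydrogen would behave on a core other than these two.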